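Three limits and an untested 2-methoxyphenyl analogue

A few compounds are considered here, and "the series" means these few. Any claim that something is new, unique, unknown or untested is made for them only; others in the source may bear on it.

Measured in a functional assay on A549 cells (Homo sapiens) for cytotoxicity, read by MTT assay, with a stated time of 72 h; on this read-out higher numbers stand for weaker inhibition and lower numbers for stronger inhibition:
- Compound 1 `COc1cccc(/C=C2\CCC/C(=C\c3ccccc3Cl)C2=O)c1OC`: > 20000 nM (a limit)
- Compound 2 `COc1cccc(/C=C2\CCC/C(=C\c3cccc(Cl)c3)C2=O)c1OC`: > 20000 nM (a limit)
- Compound 3 `COc1cccc(/C=C2\CCC/C(=C\c3ccc(Br)cc3)C2=O)c1OC`: > 20000 nM (a limit)

Compound 3 has no numerical value in this assay. Its reading of > 20000 nM is a limit of the assay. It shares that position with the other two measured compounds, as the limit of > 20000 nM in this assay, at which 3 of the 3 values shown sit, shows.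

Compound 4 `COc1ccccc1/C=C1\CCC/C(=C\c2cccc(OC)c2OC)C1=O` differs from compound 3 by 2-methoxyphenyl in place of 4-bromophenyl on a double-bonded chain carbon bound to a double-bonded ring carbon. It carries 2-methoxyphenyl in place of 4-bromophenyl on a double-bonded chain carbon bound to a double-bonded ring carbon.

Three measured steps change this same place: a step that the two limits leave unreadable from compound 1 to compound 2, a step that the two limits leave unreadable from compound 1 to compound 3 and a step that the two limits leave unreadable from compound 2 to compound 3. None has a readable size, so they offer no measured guide to the size or direction of the new step. Going by the values given here, all three show only that the aryl groups tried so far leave the compounds at the limit, and no compound with 2-methoxyphenyl at this place has been measured.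

The most likely outcome is therefore that compound 4 also reports only a limit. The expected change is a number no higher from compound 3 to compound 4 (the limit leaves the size open), with no direction firmly supported. The estimated half-maximal inhibitory concentration for compound 4 is 20000 nM, within an expected range of 7000 nM to 50000 nM.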

Compound 4, half-maximal inhibitory concentration: > 20000 nM
Compound 4 gave a limit, no number (the forecaster's own chance of this, stated with the estimate: 65%); the middle value sits exactly at the limit.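

In this assay compound 4 gives > 20000 nM as a limit and not a number. Its steps from compound 1, compound 2 and compound 3 therefore cannot be read, because all four compounds share one limit: the limit of > 20000 nM in this assay, at which 4 of the 4 values shown sit. The compounds shown leave open how strongly any of them inhibits in this assay and whether any aryl group at this place changes it.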